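Compound 4 against the phenol ether, compound 2

The source may hold more compounds than are shown below. What is called first, only, known or untested is meant among the compounds shown, and "the series" means these compounds.

Measured in a functional assay on RAW264.7 cells (Mus musculus) for inhibition, read by Griess assay, with stated times of 3 h and 24 h; a lower number here means a stronger inhibitor, a higher number a weaker inhibitor:
- Compound 1 `C=C1CCC2C(C)(CO)[C@H](O)CC[C@@]2(C)[C@@H]1CCn1c(N)nccc1=O`: > 100000 nM (a limit)
- Compound 2 `C=C1CCC2[C@](C)(CO)[C@H](O)CC[C@@]2(C)[C@@H]1CCOc1ccccc1O`: 47700 nM
- Compound 3 `C=C1CCC2[C@](C)(CO)[C@H](O)CC[C@@]2(C)[C@@H]1CCOc1ccc2ccc(=O)oc2c1`: > 50000 nM (a limit)

Going by the values given here, compound 2, at 47700 nM, carries the only actual number. The other two results are limits and give no numbers. Compound 1 remains a limit at > 100000 nM. Compound 3 remains a limit at > 50000 nM.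

The next compound to be tested is compound 4 `C=C1CCC2[C@](C)(CO)[C@H](O)CC[C@@]2(C)[C@@H]1CCOC(=O)c1cccnc1`. It has (pyridin-3-yl)carbonyl in place of 2-hydroxyphenyl on an oxygen on a saturated carbon. Seen one bond further out, this is 2-hydroxyphenoxy replaced by ((pyridin-3-yl)carbonyl)oxy.

Among the compounds with values here, no pair of measured compounds differs in one place, so the series gives no measured step to scale this change against. In this assay, no step beyond the usual scatter is expected, and any drift is expected towards weaker inhibition. The expectation rests on compound 2 at 47700 nM, the sole numerical anchor. The estimated change is a 1.0-fold higher number from compound 2 to compound 4 (0.02 log units; within the scatter). For compound 4 the expected value is 50000 nM, with an estimated range of 18000 nM to 120000 nM. A result reported only as a limit would be no surprise.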

Compound 4, half-maximal inhibitory concentration: > 50000 nM
Compound 4: no number, only a limit; the forecaster's own chance of this, stated with the estimate: 50%; the middle value sits exactly at the limit.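

In this assay compound 4 gives > 50000 nM, which is a limit of the assay and not a number. Going by these compounds alone, replacing 2-hydroxyphenoxy with ((pyridin-3-yl)carbonyl)oxy provides the only step that can be read between compounds differing in one place, and it reads as an at least 1.0-fold higher number from compound 2 to compound 4 (0.02 log units; that floor lies within the scatter), so only a floor is known for this change, and it does not establish a real loss of inhibition. The result adds no second number at this position, and compound 4 stands at the limit: the limit of > 50000 nM in this assay, at which 2 of the 4 values shown sit.

From the compounds shown here alone, the true size of the step remains open, as does whether any group on this oxygen can give a number clearly lower than that of compound 2. An amine or a carboxylic acid in place of 2-hydroxyphenoxy would test whether this position can give a second measured value in this assay.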